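Amide Variation on a Spirocyclic Cholesterol-Transporter Ligand Series

This account rests on a few compounds, and the source may have more. Where it says the series, first, only, none or still open, it means among the compounds named here.

Compound 1 `CC(C)(C)OC(=O)NCCNC(=O)CN1CN(c2ccccc2)C2(CCN(C(=O)c3ccc(C(C)(C)C)cc3)CC2)C1=O`: 10900 nM
Compound 2 `CCC1CCCN(C(=O)CN2CN(c3ccccc3)C3(CCN(C(=O)c4ccc(C(C)(C)C)cc4)CC3)C2=O)C1`: 3900 nM
Compound 3 `CC(C)(C)c1ccc(C(=O)N2CCC3(CC2)C(=O)N(CC(=O)NCCCN)CN3c2ccccc2)cc1`: 4200 nM

Of the compounds shown here, three have been measured in an assay on HEK293 cells for displacement of a labelled ligand from NPC1-like intracellular cholesterol transporter 1 (Homo sapiens); on this read-out lower numbers stand for stronger inhibition and higher numbers for weaker inhibition. Compound 3 sits second highest of the three numbers; compound 2 is its nearest neighbour, within the scatter, while compound 1 lies furthest, with a 2.6-fold lower number from compound 1 to compound 3 (0.41 log units; beyond the scatter). Compound 4 `CC(C)(C)c1ccc(C(=O)N2CCC3(CC2)C(=O)N(CC(=O)N2CCCCC2CCO)CN3c2ccccc2)cc1` differs from compound 3 in one place: 2-(2-hydroxyethyl)piperidin-1-yl in place of (3-aminopropyl)amino on a carbonyl carbon. The two steps that touch this position are a 2.8-fold lower number from compound 1 to compound 2 (0.45 log units; beyond the scatter) and a 1.1-fold higher number from compound 2 to compound 3 (0.03 log units; within the scatter). Since compound 2, which already carries a piperidine ring on that carbonyl carbon, gives 3900 nM, a ring at this place has shown no advantage over the open chain of compound 3. Compound 4 is therefore expected to stay close to compound 3, with a 1.2-fold lower number from compound 3 to compound 4 (0.08 log units; within the scatter). The estimate for compound 4 is 3500 nM, within a range of 1500 nM to 8500 nM.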

Compound 4, half-maximal inhibitory concentration: 6100 nM
For compound 4 the middle estimate is 1.7-fold (0.24 log units) below the measured one; the range from low to high includes it.
By their numbers in this assay, from the lowest: compounds 2, 3, 4 and 1 (each within the scatter of the next, the first and the last beyond it).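

In this assay the change to 2-(2-hydroxyethyl)piperidin-1-yl on this carbonyl carbon gives a 1.5-fold higher number from compound 3 to compound 4 (0.16 log units; within the scatter) and a 1.6-fold higher number from compound 2 to compound 4 (0.19 log units; within the scatter) without separating compound 4 from either the open chain or the 3-ethylpiperidin-1-yl ring. The same holds for a 1.8-fold lower number from compound 1 to compound 4 (0.25 log units; within the scatter) against the tert-butoxycarbonyl-bearing chain, so compound 4 lies within the scatter of all three earlier compounds, although compound 1 and compound 2 lie beyond it of each other. No available evidence bears on this result. From the compounds shown here alone, whether a carboxylic acid, a morpholine or a longer chain on this carbonyl carbon would move the number beyond the scatter stays open.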